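Pyridin-3-yl for pyridin-4-yl in two related cores

The compounds below may be only part of what the source reports. "The series", "measured", "known", "first", "only" and "open" are said of these compounds alone.

Measured compounds, with the read-out in a functional assay on HeLa cells (Homo sapiens) for antiproliferative activity, read by CCK-8 assay, with a stated time of 72 h, tested at 2 uM; a lower number here means a weaker effect, a higher number a stronger effect of the compound at the concentration tested:
compound 1 `Nc1ccccc1NC(=O)c1ccc(CSC(=S)N2CCN(Cc3ccncc3)CC2)cc1`: compound 1 gives 59.5%
compound 2 `Nc1ccccc1NC(=O)c1ccc(CSC(=S)N2CCN(Cc3cccnc3)CC2)cc1`: compound 2 gives 69.7%
compound 3 `CN(Cc1ccncc1)C(=S)SCc1ccc(C(=O)Nc2ccccc2N)cc1`: compound 3 gives 29.5%

Compounds 1 and 2 share one core and differ in a single place: pyridin-3-yl in place of pyridin-4-yl on a saturated chain carbon bound to an amine nitrogen in a ring. This change gives a number 10.2 percentage points higher from compound 1 to compound 2 (beyond the scatter). Compound 3 carries a different core; the difference between the two cores is not broken down here. Among the three measured compounds, compound 3 is the weakest, its steps to compound 1 and to compound 2 both lying beyond the scatter.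

Compound 4 `CN(Cc1cccnc1)C(=S)SCc1ccc(C(=O)Nc2ccccc2N)cc1` is not yet measured. It relates to compound 3 as compound 2 relates to compound 1: pyridin-3-yl in place of pyridin-4-yl on a saturated chain carbon bound to an amide-type nitrogen. The surroundings are not identical, since in compound 1 the group sits on a saturated chain carbon bound to an amine nitrogen in a ring, whereas in compound 3 it sits on a saturated chain carbon bound to an amide-type nitrogen; it is therefore the same kind of change, not the same change. The expectation for compound 4 rests on a single precedent, the step from compound 1 to compound 2, applied to the value of compound 3, with added uncertainty for the changed surroundings. The step is expected to read a number 9.5 percentage points higher from compound 3 to compound 4 (within the scatter), modest like the measured one. In this assay compound 4 is therefore estimated at 39%, within a range from 24% to 55%.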

Compound 4, a percentage reported as inhibition, at one concentration (the size of the read-out at that concentration, not a potency): 16.4%
The estimate for compound 4 lay 22.6 percentage points above the measured number; the measured number lies below the stated range.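

In this assay, the change from pyridin-4-yl to pyridin-3-yl gives a number 13.1 percentage points lower from compound 3 to compound 4 (beyond the scatter), so on this core it runs opposite to the step on the core of compound 1, and the two steps differ clearly: the same change on two cores in this assay, a number 10.2 percentage points higher (beyond the scatter) from compound 1 to compound 2 and a number 13.1 percentage points lower (beyond the scatter) from compound 3 to compound 4, 23.3 percentage points apart, beyond the scatter of two such steps

In these two pairs, the effect of this change therefore does not carry from one core to the other as a fixed increment or even as a fixed direction, and neither pyridine attachment can be called the better one for the series as a whole. For the compounds shown here, this does not show which feature of the cores sets the direction, whether the amine nitrogen in a ring, the amide-type nitrogen or some other part of the difference between them, and it rests on only one pair per core, each read at a single concentration, which gives no potency.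

The compounds shown leave open how pyridin-2-yl or a plain phenyl ring in the same place would read on each core, and so whether the opposite steps belong to the pyridine nitrogen at all. They also leave open whether the reversal would persist on further cores, such as one carrying a longer chain in place of the methyl group of compound 3.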